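Methylcarbamoyl in Place of Methyl on the Aryl Ring

The source may report more compounds than this note shows. Statements on the series, on what has been measured and on what is new or still open speak of the compounds shown alone.

Compound 1 `C=CC[C@H]1C[C@]2([C@@H](C)Cc3ccc(OC)c(OC)c3)OCOC2=CC1=O`: in a functional assay on NCI-H460 cells (Homo sapiens) for antiproliferative activity, with a stated time of 72 h (on this read-out lower numbers stand for stronger inhibition and higher numbers for weaker inhibition), compound 1 gives 260 nM.
Compound 2 `C=CC[C@@H]1C[C@]2([C@H](C)Cc3ccc(OC)c(OC)c3)OCOC2=CC1=O`: in this assay compound 2 reaches only a limit, > 4000 nM.
Compound 3 `C=CC[C@H]1C[C@]2([C@@H](C)Cc3ccc(OC)c(C)c3)OCOC2=CC1=O`: in this assay compound 3 gives 630 nM.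

Compound 3 stands highest of the two numbers reported; its nearest neighbour is compound 1, and the step of a 2.4-fold higher number from compound 1 to compound 3 (0.38 log units; beyond the scatter) is modest, tied to methyl in place of methoxy on an aromatic carbon. The other measured step, an at least 15-fold higher number from compound 1 to compound 2 (1.18 log units; beyond the scatter), is large and rests on the fact that compounds 1 and 2 differ only in the configuration as drawn and (the limit of > 4000 nM in this assay, at which 1 of the 3 values shown sits); it concerns configuration alone and does not bear on the present change. Compound 4 `C=CC[C@H]1C[C@]2([C@@H](C)Cc3ccc(OC)c(C(=O)NC)c3)OCOC2=CC1=O` differs from compound 3 by methylcarbamoyl in place of methyl on an aromatic carbon. For the measured compounds named here, no measured step tests this group, so the expectation is loosely held. Compound 4 is expected to give 1000 nM in this assay, between 300 nM and 4000 nM. That amounts to an estimated step of a 1.6-fold higher number from compound 3 to compound 4 (0.20 log units; within the scatter), toward a somewhat higher number.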

Compound 4, half-maximal inhibitory concentration: 1100 nM
Estimate against measurement, compound 4: 1.1-fold (0.04 log units) below, and the stated range covers the measured number.
By their numbers in this assay, from the lowest: compound 1; then compounds 3 and 4 (each within the scatter of the next). At a limit, above all of these: compound 2.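

In this assay, the position ortho to a methoxy group accepts methylcarbamoyl in place of methyl, adding a hydrogen-bond donor and acceptor, with a 1.7-fold higher number from compound 3 to compound 4 (0.24 log units; within the scatter). Against the methoxy group of compound 1, the same change of group gives a 4.2-fold higher number from compound 1 to compound 4 (0.63 log units; beyond the scatter), so compound 1 keeps the lowest number of the three groups at this position. Nothing measured here bears on why these groups compare this way.

From the compounds shown here alone, whether the amide hydrogen matters stays open, and dimethylcarbamoyl would test that. Going by these compounds, how an amine or a carboxylic acid would fare at this position also stays open.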